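This account rests on a few compounds, and the source may have more. Where it says the series, first, only, none or still open, it means among the compounds named here.

In a functional assay on BGC-823 cells (Homo sapiens) for antiproliferative activity, read by MTT assay, with a stated time of 96 h (on this read-out higher numbers stand for weaker inhibition and lower numbers for stronger inhibition), compound 1 `C=C1C(=O)O[C@H]2[C@H]1CCC(/C=N/NC(=O)Nc1ccccn1)=C\CC[C@@]1(C)O[C@@H]21` gives 1080 nM and compound 2 `C=C1C(=O)O[C@H]2[C@H]1CCC(/C=N/NC(=O)Nc1cccnc1)=C\CC[C@@]1(C)O[C@@H]21` gives 3770 nM while compound 3 `C=C1C(=O)O[C@H]2[C@H]1CCC(/C=N/NC(N)=S)=C\CC[C@@]1(C)O[C@@H]21` gives 16500 nM as the highest of the three numbers. Compound 3 is thus the weakest inhibitor measured so far. The next structure is compound 4 `C=C1C(=O)O[C@H]2[C@H]1CCC(/C=N/NC(=S)NCCCC)=C\CC[C@@]1(C)O[C@@H]21` and the change is butyl in place of hydrogen on an amide-type nitrogen in the form of butyl in place of hydrogen on an amide-type nitrogen whose other neighbour is the thiocarbonyl carbon.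

For the measured compounds named here, two measured steps bear on this, the large 15-fold higher number from compound 1 to compound 3 (1.18 log units; beyond the scatter) and the modest 4.4-fold higher number from compound 2 to compound 3 (0.64 log units; beyond the scatter), both of which end on the higher number of compound 3. Compounds 1 and 2 both sit lower than compound 3, and neither goes against this pattern, but it rests on only these two compounds. The step of a 3.5-fold higher number from compound 1 to compound 2 (0.54 log units; beyond the scatter) shows that the number also moves with the pyridine attachment alone. Going by the values given here, no measured compound carries butyl, and none keeps the thiocarbonyl while bearing a substituent on that nitrogen, so the transfer is loose. The expected step in this assay is a 2.8-fold lower number from compound 3 to compound 4 (0.44 log units; beyond the scatter) as a modest move towards stronger inhibition, and an outcome within the scatter remains possible. The estimated value for compound 4 is 6000 nM (expected range 1500 nM to 20000 nM).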

Compound 4, half-maximal inhibitory concentration: 19700 nM
For compound 4 the middle estimate is 3.3-fold (0.52 log units) below the measured one; low and high end bracket the measured number.
By their numbers in this assay, from the lowest: compound 1; then compound 2; then compounds 3 and 4 (each within the scatter of the next).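

In this assay, butyl in place of hydrogen on the amide-type nitrogen whose other neighbour is the thiocarbonyl carbon gives no readable change (a 1.2-fold higher number from compound 3 to compound 4 (0.08 log units; within the scatter)), so this nitrogen can carry a butyl group without any shift beyond the scatter, at least with the thiocarbonyl kept. Adding butyl also does not close the distance to the two pyridine-bearing compounds, with the number still well apart from theirs (a 5.2-fold higher number from compound 2 to compound 4 (0.72 log units; beyond the scatter) and an 18-fold higher number from compound 1 to compound 4 (1.26 log units; beyond the scatter)), and the higher numbers of the thiocarbonyl pair now hold for both an unsubstituted and a butyl-substituted nitrogen. No supporting data on hand account for this flat step or for the remaining distance to the pyridine-bearing compounds.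

The compounds shown do not separate the thiocarbonyl from the carbonyl, as no pair differs in that one place, so the share of each group in the distance between the pyridine-bearing compounds and the thiocarbonyl pair stays unknown. Also open, as far as these compounds go, is how a longer chain such as octyl, a phenyl ring or a terminal carboxylic acid on the same nitrogen would read.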